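A few compounds are considered here, and "the series" means these few. Any claim that something is new, unique, unknown or untested is made for them only; others in the source may bear on it.

Measured compounds:
Compound 1 `CCCNc1nc(N)nc2c1ncn2/C=C1/CC1(CO)CO`. In an ADME assay on CCRF-HSB-2 cells (Homo sapiens) for cytotoxicity, with a stated time of 7 days (a higher number here means that more compound is tolerated, a lower number that less compound is tolerated), compound 1 gives > 20000 nM, which is a limit of the assay and not a number.
Compound 2 `CCCOc1nc(N)nc2c1ncn2/C=C1/CC1(CO)CO`. In this assay compound 2 gives > 20000 nM, again a limit.
Compound 3 `Nc1nc(NC2CCCC2)c2ncn(/C=C3/CC3(CO)CO)c2n1`. In this assay compound 3 gives > 20000 nM, also a limit.

Compound 3 therefore stands at the ceiling of what has been measured: the limit of > 20000 nM in this assay, at which 3 of the 3 values shown sit, and no value among the three sets it apart from the others. The steps between the measured compounds are accordingly not readable: a step that the two limits leave unreadable from compound 1 to compound 2, a step that the two limits leave unreadable from compound 1 to compound 3 and a step that the two limits leave unreadable from compound 2 to compound 3.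

Compound 4 `CCOc1nc(N)nc2c1ncn2/C=C1/CC1(CO)CO` has not yet been measured in this assay. It differs from compound 3 by ethoxy in place of cyclopentylamino on an aromatic carbon. The measured step that comes closest in kind is a step that the two limits leave unreadable from compound 2 to compound 3, which exchanges an alkoxy for the cyclopentylamino in the other direction; its size is unreadable, so it gives no direction and no magnitude for the present change, only that both ends sat at the limit. The expectation is thus that the step from compound 3 to compound 4 is a step that the limit leaves unreadable from compound 3 to compound 4, nothing beyond the scatter that the data could show. Compound 4 is expected to give about 40000 nM in this assay, within 20000 nM to 200000 nM, most probably reported only as a limit.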

Compound 4, half-maximal cytotoxic concentration: > 20000 nM
Compound 4 was reported as a limit; the forecaster's own chance of this, stated with the estimate: 85%; the middle value does not contradict the limit.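

In this assay compound 4 gives > 20000 nM, a limit and not a number. Its steps to compound 1, compound 2 and compound 3 therefore cannot be read: the limit of > 20000 nM in this assay, at which 4 of the 4 values shown sit.

The compounds shown leave open whether propylamino, propoxy, cyclopentylamino and ethoxy on the shared core differ at all in tolerated concentration.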